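Swapping methylsulfonyl for chloro on the shared core

The source may report more compounds than this note shows. Statements on the series, on what has been measured and on what is new or still open speak of the compounds shown alone.

Measured in a functional assay (aorta) with Rattus norvegicus as the target; on this read-out higher numbers stand for an effect only at larger amounts of compound and lower numbers for an effect already at smaller amounts:
- Compound 1 `CN(C)/C(=N\C#N)C1=CC(C)(C)Oc2ccc(S(=O)(=O)c3ccccc3)cc21` gives 3310 nM
- Compound 2 `CN(C)/C(=N\C#N)C1=CC(C)(C)Oc2ccc(S(C)(=O)=O)cc21` gives > 31600 nM

Compound 2 gives > 31600 nM, which is a limit of this assay and not a number. Its true position is therefore unknown, and any comparison with it has only one open side.

Among the compounds with values here, the only measured step is an at least 9.5-fold higher number from compound 1 to compound 2 (0.97 log units; beyond the scatter), and the two compounds differ only in the group attached to the sulfonyl. This step lies beyond the usual scatter, so what is attached to the sulfonyl matters here.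

Compound 3 `CN(C)/C(=N\C#N)C1=CC(C)(C)Oc2ccc(Cl)cc21` has not yet been measured. It carries chloro in place of methylsulfonyl on an aromatic carbon. Within the data shown here, the sulfonyl is gone altogether, so the measured step is only a loose guide, and no measured step shows what chloro does. Compound 1 at 3310 nM does show that the shared core can give a real number in this assay. A lower number than the limit of compound 2 is therefore expected, though compound 3 may also stay at that limit.

The expected change is an at least 3.1-fold lower number from compound 2 to compound 3 (0.49 log units; beyond the scatter). For compound 3 the estimated value is 10000 nM, with an expected range from 2500 nM to 31600 nM.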

Compound 3, half-maximal effective concentration: > 31600 nM
Compound 3 was reported as a limit (the forecaster's own chance of this, stated with the estimate: 30%); middle value at least 3.1-fold (0.49 log units) away from the limit.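

In this assay compound 3 gives > 31600 nM, which is a limit of the assay and not a number. Putting chloro in place of phenylsulfonyl on this aromatic carbon gives an at least 9.5-fold higher number from compound 1 to compound 3 (0.97 log units; beyond the scatter), so removing the sulfonyl altogether does not restore a readable number, and among the three compounds shown only the one with phenylsulfonyl gives one. The comparison of chloro with methylsulfonyl cannot be read, so neither group can be ranked over the other, because both values are limits: the limit of > 31600 nM in this assay, at which 2 of the 3 values shown sit.

The compounds shown leave open whether any group without a sulfonyl can give a readable number at this aromatic carbon, as a phenoxy group or an amine might or might not. They also leave open whether the phenyl ring itself is needed on the sulfonyl, or whether a longer chain such as butyl in its place would also bring the value of the shared core down from the limit.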